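The compounds below may be only part of what the source reports. "The series", "measured", "known", "first", "only" and "open" are said of these compounds alone.

- Compound 1 `COc1cc(/C=C/C(=O)c2cccc(NC(=O)c3c(Cl)cccc3Cl)c2)ccc1O`: 2.48 ug/mL
- Compound 2 `COc1cc(/C=C/C(=O)c2cccc(NC(=O)c3ccc(Cl)cc3)c2)ccc1O`: 3.82 ug/mL

In a functional assay on Vero cells (Chlorocebus sabaeus) for inhibition (a higher number here means a weaker inhibitor, a lower number a stronger inhibitor), compound 2 gives 3.82 ug/mL, which lies within the scatter of compound 1. Compound 3 `COc1cc(/C=C/C(=O)c2cccc(N)c2)ccc1O` is the next to be measured, and its structure differs from that of compound 2 as follows: hydrogen in place of (4-chlorophenyl)carbonyl on a nitrogen on an aromatic ring. Among the measured compounds shown here, the only measured step, a 1.5-fold higher number from compound 1 to compound 2 (0.19 log units; within the scatter), exchanges the aromatic group on the carbonyl and does not remove the whole group, so it offers only weak guidance. A modest move to a higher number is tentatively expected, an estimated 1.6-fold higher number from compound 2 to compound 3 (0.20 log units; within the scatter). Compound 3 is estimated at 6 ug/mL, with an expected range of 2 ug/mL to 20 ug/mL.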

Compound 3, half-maximal inhibitory concentration: 6.02 ug/mL
The estimate for compound 3 lay 1.0-fold (0.00 log units) below the measured number, and the stated range covers the measured number.
By their numbers in this assay, from the lowest: compounds 1, 2 and 3 (each within the scatter of the next, the first and the last beyond it).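

In this assay, hydrogen in place of (4-chlorophenyl)carbonyl on the nitrogen gives a 1.6-fold higher number from compound 2 to compound 3 (0.20 log units; within the scatter), while hydrogen in place of (2,6-dichlorophenyl)carbonyl gives a 2.4-fold higher number from compound 1 to compound 3 (0.39 log units; beyond the scatter). Removing the entire acyl group, aromatic ring included, therefore shifts the number by no more than a modest step in these two pairs, so that group is not required for inhibition at this level. Nothing available explains this result. The compounds shown leave open how a small acetyl group or a methyl group on that nitrogen would read, and whether a sulfonamide could replace the amide.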